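This account rests on a few compounds, and the source may have more. Where it says the series, first, only, none or still open, it means among the compounds named here.

Measured in a functional assay on P815 cells (Mus musculus) for antiproliferative activity; a lower number here means a stronger inhibitor, a higher number a weaker inhibitor: compound 1 `Nc1nc(=O)n(C2OC(CO)C(I)C2O)cc1F` gives 8 ug/mL; compound 3 `CS(=O)(=O)O[C@@H]1[C@@H](O)[C@H](n2cc(F)c(N)nc2=O)O[C@@H]1CO` gives 6 ug/mL. Compound 2 `Cc1ccc(S(=O)(=O)O[C@@H]2[C@@H](O)[C@H](n3ccc(N)nc3=O)O[C@@H]2CO)cc1` gives only a limit, > 30 ug/mL, not a number.

Compound 3 has the lowest of the two numbers, with compound 1 close by and the gap within the scatter. Compound 4 `Cc1ccc(S(=O)(=O)O[C@@H]2[C@@H](O)[C@H](n3cc(F)c(N)nc3=O)O[C@@H]2CO)cc1` differs from compound 3 at the sulfonyl sulfur (4-methylphenyl in place of methyl on a sulfonyl sulfur). Among the measured compounds shown here, no measured pair makes this same change, so its effect cannot be read off directly. The other 4-methylphenyl sulfonate, compound 2, sits at the limit of > 30 ug/mL in this assay, at which 1 of the 3 values shown sits.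

In this assay the step of a 2.5-fold higher number from compound 3 to compound 4 (0.40 log units; beyond the scatter) is expected to be a modest move toward a higher number, not far beyond the scatter. Compound 4 is therefore estimated at 15 ug/mL, between 5 ug/mL and 40 ug/mL.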

Compound 4, concentration for 50% inhibition: 3.9 ug/mL
Beside the measured number, compound 4's estimate is 3.8-fold (0.59 log units) above it, outside the stated range (below it).
By their numbers in this assay, from the lowest: compounds 4, 3 and 1 (each within the scatter of the next, the first and the last beyond it). At a limit, above all of these: compound 2.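

In this assay, the larger group on the sulfonyl sulfur costs nothing measurable when the fluoro is present: a 1.5-fold lower number from compound 3 to compound 4 (0.19 log units; within the scatter), so methyl and 4-methylphenyl cannot be told apart at this place. Compound 2 is held only at a limit, not a number: the limit of > 30 ug/mL in this assay, at which 1 of the 4 values shown sits. Fluoro in place of hydrogen on an aromatic carbon gives an at least 7.6-fold lower number from compound 2 to compound 4 (0.88 log units; beyond the scatter), so the 4-methylphenyl group alone does not fix the result at that limit.

From the compounds shown here alone, whether a longer chain or an amine on the sulfonyl sulfur would fit as well remains open. So does whether the fluoro step holds with methyl on the sulfur.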